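The source may hold more compounds than are shown below. What is called first, only, known or untested is meant among the compounds shown, and "the series" means these compounds.

In a functional assay on DU-145 cells (Homo sapiens) for antiproliferative activity, read by propidium iodide staining, with a stated time of 96 h (on this read-out higher numbers stand for weaker inhibition and lower numbers for stronger inhibition), compound 1 (`CC(O)(CSc1ccccc1C(F)(F)F)C(=O)Nc1ccc(S(F)(F)(F)(F)F)cc1`) gives 15800 nM and compound 2 (`CC(O)(CS(=O)(=O)c1cccc(C(F)(F)F)c1)C(=O)Nc1ccc(S(F)(F)(F)(F)F)cc1`) gives 31900 nM while compound 3 (`CC(O)(CS(=O)(=O)c1cc(C(F)(F)F)cc(C(F)(F)F)c1)C(=O)Nc1ccc(S(F)(F)(F)(F)F)cc1`) gives 24400 nM on the same read-out. Compound 3 lies within the scatter of both other compounds, so the numbers set it apart from neither. Going by the values given here, compound 4 (`CC(O)(CS(=O)(=O)c1cc(C(F)(F)F)cc(C(F)(F)F)c1)C(=O)Nc1cccc(S(F)(F)(F)(F)F)c1`) has the same atoms as compound 3, joined differently, with a group of 12 heavy atoms (6 carbon, 5 fluorine, 1 sulfur; one six-membered aromatic ring of carbon only) in place of a group of 12 heavy atoms (6 carbon, 5 fluorine, 1 sulfur; one six-membered aromatic ring of carbon only), on an amide-type nitrogen as the sole change. Among the compounds with values here, the one measured step is a 1.3-fold lower number from compound 2 to compound 3 (0.12 log units; within the scatter) and it leaves the amide-type nitrogen untouched. Within the data shown here, no measured pair alters the group on that nitrogen, so direct precedent is missing. Taking the small size of that one step as the only guide, and compound 3 at 24400 nM as the anchor, no shift beyond the scatter is expected in this assay and no direction is favoured. The expected change is small (an estimated 1.1-fold lower number from compound 3 to compound 4 (0.04 log units; within the scatter)). For compound 4 the estimated value is 22000 nM with an expected range from 9000 nM to 50000 nM on this read-out.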

Compound 4, half-maximal inhibitory concentration: 13700 nM
Compound 4: middle estimate off by 1.6-fold (0.21 log units), on the high side, within the range that was stated.
By their numbers in this assay, from the lowest: compounds 4, 1, 3 and 2 (each within the scatter of the next, the first and the last beyond it).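

In this assay, going by these compounds alone, the only step so far at the amide-type nitrogen is a 1.8-fold lower number from compound 3 to compound 4 (0.25 log units; within the scatter), and it stays within the scatter. Within the data shown here, on this pair, therefore, the two arrangements of the same 12 heavy atoms on that nitrogen are not told apart on this read-out, which the earlier compounds, all sharing a single group there, could not show. Nothing available bears on why the two compounds read as they do.

Among these compounds, the change is seen only on the core of compound 3, so whether it holds on the core of compound 1 or compound 2 remains open. All compounds shown carry the same 12 heavy atoms on the amide-type nitrogen, leaving open what a ring bearing a nitrile, an amine or a carboxylic acid would give there.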